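The source may report more compounds than this note shows. Statements on the series, on what has been measured and on what is new or still open speak of the compounds shown alone.

Measured so far in a functional assay on CCRF-CEM cells (Homo sapiens) for cytotoxicity; on this read-out higher numbers stand for weaker inhibition and lower numbers for stronger inhibition:

Compound 1, `Cc1ccc(NC(=O)/C=C/C(=O)N2C/C(=C\c3ccc([N+](=O)[O-])cc3)C(=O)/C(=C/c3ccc([N+](=O)[O-])cc3)C2)cc1C`: 700 nM
Compound 2, `Cc1ccc(NC(=O)/C=C/C(=O)N2C/C(=C\c3ccc([N+](=O)[O-])cc3)C(=O)/C(=C/c3ccc([N+](=O)[O-])cc3)C2)cc1`: 890 nM
Compound 3, `CC(=O)c1ccc(NC(=O)/C=C/C(=O)N2C/C(=C\c3ccc([N+](=O)[O-])cc3)C(=O)/C(=C/c3ccc([N+](=O)[O-])cc3)C2)cc1`: 360 nM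

Compound 3 has the lowest of the three numbers in this assay. One of its two gaps is a 1.9-fold lower number from compound 1 to compound 3 (0.29 log units; within the scatter), which does not separate the two, whereas the other is a 2.5-fold lower number from compound 2 to compound 3 (0.39 log units; beyond the scatter). Compound 4, `O=C(/C=C/C(=O)N1C/C(=C\c2ccc([N+](=O)[O-])cc2)C(=O)/C(=C/c2ccc([N+](=O)[O-])cc2)C1)Nc1ccc(Cl)cc1`, differs from compound 3 in one place: chloro in place of acetyl on an aromatic carbon.

Going by the values given here, no measured step brings in a chloro group, so the closest guide is the step of a 2.5-fold lower number from compound 2 to compound 3 (0.39 log units; beyond the scatter), in which the acetyl group gave a lower number than methyl. The step of a 1.3-fold higher number from compound 1 to compound 2 (0.10 log units; within the scatter) shows that removing a methyl group changed little. Taking the acetyl group away again in compound 4, the expectation is a move back up toward the numbers of compound 1 and compound 2, with the chloro group itself an unknown. The step is expected to be a 1.8-fold higher number from compound 3 to compound 4 (0.26 log units; within the scatter), a rise that may sit at the edge of the scatter. Compound 4 is therefore estimated at 650 nM in this assay, within a range of 320 nM to 1400 nM.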

Compound 4, half-maximal inhibitory concentration: 810 nM
For compound 4 the middle estimate is 1.2-fold (0.10 log units) below the measured one; low and high end bracket the measured number.
By their numbers in this assay, from the lowest: compounds 3, 1, 4 and 2 (each within the scatter of the next, the first and the last beyond it).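

At this aromatic carbon in this assay, chloro does not keep what acetyl gained: a 2.3-fold higher number from compound 3 to compound 4 (0.35 log units; beyond the scatter) is a step beyond the scatter, so acetyl now stands apart from chloro as well as from methyl. Chloro and methyl at this carbon cannot be told apart, as a 1.1-fold lower number from compound 2 to compound 4 (0.04 log units; within the scatter) lies within the scatter. The 4-chlorophenyl and 3,4-dimethylphenyl groups likewise stay together, with a 1.2-fold higher number from compound 1 to compound 4 (0.06 log units; within the scatter) also within the scatter, so the two groups other than acetyl give no order among these compounds.

Going by these compounds, whether the lower number belongs to acetyl alone or to any group carrying a carbonyl stays open, and a longer ketone chain, a nitrile, a carboxylic acid or an amine at this carbon would bear on that. Nothing given here accounts for the gap between acetyl and chloro.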